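The compounds below may be only part of what the source reports. "The series", "measured", "known", "first", "only" and "open" are said of these compounds alone.

Within the data shown here, in a toxicity assay on MDCK cells (Canis lupus familiaris) for cytotoxicity, read by MTT assay, with a stated time of 48 h (on this read-out higher numbers stand for lower toxicity in this test and lower numbers for higher toxicity in this test), compound 2 `CC(C)(C)c1ccc(C(=O)/N=c2\[nH]c3ccccc3n2CCOc2ccc(Br)cc2)cc1` gives 2030000 nM, the only plain number among the two values measured. Compound 1 `COc1ccc(OCCn2/c(=N/C(=O)c3cccs3)[nH]c3ccccc32)cc1` reaches only a limit, > 2540000 nM, in this assay and yields no number. Compound 3 `O=C(/N=c1\[nH]c2ccccc2n1CCOc1ccc(Br)cc1)c1cccs1` differs from compound 2 by thiophen-2-yl in place of 4-(tert-butyl)phenyl on a carbonyl carbon. Among the measured compounds shown here, no step between measured compounds connects these two, so no measured size guides the change. The step is expected to be a 1.2-fold higher number from compound 2 to compound 3 (0.09 log units; within the scatter), small and toward lower toxicity or none beyond the scatter; this rests on (the limit of > 2540000 nM in this assay, at which 1 of the 2 values shown sits), which compound 1 reaches while also carrying thiophen-2-yl on the carbonyl carbon. Compound 3 is therefore estimated at 2500000 nM, within 1200000 nM to 5000000 nM.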

Compound 3, half-maximal cytotoxic concentration: > 2260000 nM
Compound 3: only a limit was reported; the forecaster's own chance of this, stated with the estimate: 40%; the middle value is on the limit's open side.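

Among these compounds, at the carbonyl carbon, thiophen-2-yl in place of 4-(tert-butyl)phenyl gives the first readable step in this assay: an at least 1.1-fold higher number from compound 2 to compound 3 (0.04 log units; that floor lies within the scatter). Compound 3 gives only a limit, so this step is a floor with no upper end: the limit of > 2260000 nM in this assay, at which 1 of the 3 values shown sits. The step from compound 1 to compound 3, bromo in place of methoxy on an aromatic carbon, cannot be read. Going by these compounds, how far past its limit compound 3 lies stays open. Also open, on these data alone, is what a longer chain ending in an amine would give on the carbonyl carbon in this assay.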